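Oxindole series: methoxy for chloro at the para-fused position

This account rests on a few compounds, and the source may have more. Where it says the series, first, only, none or still open, it means among the compounds named here.

Measured compounds:
compound 1 `COc1cc2c(/C=C3/C(=O)Nc4ccc(O)cc43)c(Cl)n(Cc3cc(OC)c(OC)c(OC)c3)c2cc1C`, 49000 nM
compound 2 `COc1cc2c(/C=C3/C(=O)Nc4ccc(Cl)cc43)c(Cl)n(Cc3cc(OC)c(OC)c(OC)c3)c2cc1C`, 5620 nM

Both numbers come from a functional assay on cells (Cancer cell lines, Homo sapiens) for cytotoxicity, with a stated time of 48 h; a higher number here means a weaker inhibitor of growth, a lower number a stronger inhibitor of growth. Compound 2 gives the lowest of the two numbers measured; the nearest is compound 1, which gives 49000 nM in this assay. For the measured compounds named here, the only step measured so far, an 8.7-fold lower number from compound 1 to compound 2 (0.94 log units; beyond the scatter), arises from chloro in place of hydroxy on an aromatic carbon.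

Compound 3 `COc1ccc2c(c1)/C(=C\c1c(Cl)n(Cc3cc(OC)c(OC)c(OC)c3)c3cc(C)c(OC)cc13)C(=O)N2` carries a different substitution at that same place: methoxy in place of chloro on an aromatic carbon. Going by the values given here, no step with a methoxy group at this position has been measured. Among the compounds with values here, the one step that bears on it, an 8.7-fold lower number from compound 1 to compound 2 (0.94 log units; beyond the scatter), shows that the chloro group gave a lower number than the hydroxy group. Methoxy is neither of these, so the direction is taken from the fact that any departure from chloro here has so far given a higher number. Compound 3 is therefore expected to show a 2.7-fold higher number from compound 2 to compound 3 (0.43 log units; beyond the scatter), a rise in the number, though smaller than the step back to compound 1. The estimate for compound 3 in this assay is 15000 nM, with a range of 5000 nM to 45000 nM.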

Compound 3, concentration for total growth inhibition: 85100 nM
Beside the measured number, compound 3's estimate is 5.7-fold (0.75 log units) below it; the measured number lies above the stated range.
By their numbers in this assay, from the lowest: compound 2; then compounds 1 and 3 (each within the scatter of the next).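

In this assay, for the compounds shown here, methoxy in place of chloro gives a 15-fold higher number from compound 2 to compound 3 (1.18 log units; beyond the scatter) and is the largest step so far, so a second replacement for chloro also costs activity, and compound 2 remains the only compound separated from the others. Methyl in place of hydrogen on the oxygen gives a 1.7-fold higher number from compound 1 to compound 3 (0.24 log units; within the scatter) and leaves hydroxy and methoxy indistinguishable in this read-out, so adding that methyl brings no measurable change here. With three compounds, the pattern is therefore chloro on one side and the two oxygen-linked groups together on the other, with no exception among them. No supporting measurement bears on why chloro stands apart.

From the compounds shown here alone, whether the lower number is specific to chloro or extends to other halogens remains open, as bromo, fluoro or an atom-free hydrogen at this aromatic carbon would test that. Going by these compounds, it is equally open how a carbon-linked group such as methyl or trifluoromethyl, or a nitrogen-linked one such as an amine, would compare with chloro in cells.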